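Amide aryl chloro placement in the shared core series

The compounds below may be only part of what the source reports. "The series", "measured", "known", "first", "only" and "open" are said of these compounds alone.

Of the compounds shown here, three of the shared core have been measured in a functional assay on MCF7 cells (Homo sapiens) for antiproliferative activity, read by MTT assay, with a stated time of 72 h; a lower number here means a stronger inhibitor, a higher number a weaker inhibitor. Compound 3 `O=C(Nc1ccc(Cl)c(-c2nnc3c(Cl)cccn23)c1)c1cccc(Cl)c1` gives 71900 nM. Compound 1 `O=C(Nc1ccc(Cl)c(-c2nnc3c(Cl)cccn23)c1)c1ccc(C(F)(F)F)cc1F` gives 62800 nM in this assay; the two values sit within the scatter of each other. For compound 2 `O=C(Nc1ccc(Cl)c(-c2nnc3c(Cl)cccn23)c1)c1ccccc1` this assay returns only a limit, > 100000 nM, which is not a number (the limit of > 100000 nM in this assay, at which 1 of the 3 values shown sits). Among the values shown, compound 3 therefore stands with compound 1 at the measurable end, while compound 2 lies at the limit.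

Within the data shown here, the one measured step in this assay is an at least 1.3-fold lower number from compound 2 to compound 3 (0.14 log units; that floor lies within the scatter); it shows that chloro in place of hydrogen on the aromatic carbon brings the number down out of the limit, though by a floor that lies within the scatter.

Compound 4 `O=C(Nc1ccc(Cl)c(-c2nnc3c(Cl)cccn23)c1)c1ccccc1Cl` differs from compound 3 by 2-chlorophenyl in place of 3-chlorophenyl on a carbonyl carbon. No measured step moves the chloro from one position of the aryl ring to another, so nothing shown speaks to the size or direction of this change; only the chloro-versus-hydrogen step exists, and it is small. The step from compound 3 to compound 4 is therefore expected to be a 1.0-fold higher number from compound 3 to compound 4 (0.02 log units; within the scatter), within the scatter. Compound 4 is estimated at 75000 nM, with a range from 35000 nM to 150000 nM in this assay.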

Compound 4, half-maximal inhibitory concentration: 92200 nM
Compound 4: middle estimate off by 1.2-fold (0.09 log units), on the low side; measured number inside the range.
By their numbers in this assay, from the lowest: compounds 1, 3 and 4 (each within the scatter of the next). At a limit, above all of these: compound 2.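

Moving the chloro from 3-chlorophenyl to 2-chlorophenyl on the carbonyl carbon is now a measured change in this assay, and it reads as a 1.3-fold higher number from compound 3 to compound 4 (0.11 log units; within the scatter), so the two chloro placements are not separated by this assay. Chloro in place of hydrogen now has a second measured case, an at least 1.0-fold lower number from compound 2 to compound 4 (0.03 log units; that floor lies within the scatter), and like the first it gives only a floor within the scatter, so neither placement is shown to differ from the hydrogen parent by a real margin. Compound 2 holds a limit and not a number, which is what keeps both chloro-for-hydrogen steps as floors: the limit of > 100000 nM in this assay, at which 1 of the 4 values shown sits.

As far as these compounds go, whether an amine, a carboxylic acid or a methoxy group on this aryl ring would give a number clearly apart from compound 1, compound 3 and compound 4 remains open, since the measured values of these three all lie within the scatter of one another. Also open, from the compounds shown here alone, is whether any change at this carbonyl substituent on the shared core can reach a markedly lower number in this assay.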